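The compounds below may be only part of what the source reports. "The series", "measured", "known", "first", "only" and "open" are said of these compounds alone.

Compound 1 `COc1cc(CNc2nc3cc(N)cc(N)c3nc2-c2ccccc2)cc(OC)c1OC` gives 37200 nM in a functional assay on HCT-116 cells (Homo sapiens) for inhibition, read by sulforhodamine B assay, with a stated time of 48 h; a lower number here means that less compound is tolerated, a higher number that more compound is tolerated. Compound 2 `COc1ccc(Sc2nc3cc(N)cc(N)c3nc2-c2ccccc2)cc1` gives < 100000 nM in this assay, which is a limit of the assay and not a number.

Among the compounds with values here, compound 2 therefore stands only at the limit of < 100000 nM in this assay, at which 1 of the 2 values shown sits, while compound 1 is the one compound with a numerical value, and no step between compound 1 and compound 2 is worked out here. Compound 3 `Nc1cc(N)c2nc(-c3ccccc3)c(Oc3ccc(F)cc3)nc2c1` differs from compound 2 by a single exchange: 4-fluorophenoxy in place of (4-methoxyphenyl)sulfanyl on an aromatic carbon. Within the data shown here, since compound 2 offers only a limit, there is no measured step from which to read this exchange. The expected step that the limit leaves unreadable from compound 2 to compound 3 is therefore set near none beyond the usual scatter, with wide uncertainty in both directions. Compound 3 is expected to give about 40000 nM in this assay, somewhere between 10000 nM and 100000 nM, and a reading that again ends at a limit remains quite possible.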

Compound 3, concentration lethal to 50% of the cells: < 100000 nM
Compound 3: only a limit was reported; the forecaster's own chance of this, stated with the estimate: 40%; the middle value lies beyond the limit too.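

Compound 2 and compound 3 both end at a limit, not a number, in this assay, so no step can be read for 4-fluorophenoxy in place of (4-methoxyphenyl)sulfanyl: the limit of < 100000 nM in this assay, at which 2 of the 3 values shown sit. The compounds shown leave open whether this exchange shifts the value at all, and in which direction.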